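Furan for phenyl on the thiazole side of the core

The compounds below may be only part of what the source reports. "The series", "measured", "known", "first", "only" and "open" are said of these compounds alone.

Measured so far:
compound 1 `COc1cccc(-c2nc(N)c3nc(-c4ccccc4)sc3n2)c1` — 35.6 nM
compound 2 `Cc1ccc(-c2nc(N)c3nc(-c4ccccc4)sc3n2)o1` — 24.9 nM

Compound 1 and compound 2 share one core and differ only in the aryl group on the pyrimidine carbon. In an assay on CHO cells for displacement of a labelled ligand from adenosine receptor A3 (Homo sapiens), read by scintillation counting, with a stated time of 3 h (on this read-out lower numbers stand for stronger inhibition and higher numbers for weaker inhibition), compound 1 gives 35.6 nM, the higher of the two numbers; its nearest neighbour is compound 2 with 24.9 nM, and the step of a 1.4-fold lower number from compound 1 to compound 2 (0.16 log units; within the scatter) stays within the scatter.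

Compound 3 `COc1cccc(-c2nc(N)c3nc(-c4ccco4)sc3n2)c1` keeps the 3-methoxyphenyl of compound 1 and alters the other ring: furan-2-yl in place of phenyl on an aromatic carbon. Within the data shown here, no measured step touches this position, so the only measured change, a 1.4-fold lower number from compound 1 to compound 2 (0.16 log units; within the scatter), does not bear on it and offers no direct guide. Without such a precedent, a step of modest size or none beyond the scatter is the expectation for this assay. Compound 3 is expected at 50 nM, in the range 15 nM to 170 nM. The expected step from compound 1 is a 1.4-fold higher number from compound 1 to compound 3 (0.15 log units; within the scatter).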

Compound 3, inhibition constant: 4.9 nM
The estimate for compound 3 lay 10-fold (1.01 log units) above the measured number, and the stated range ends above it.
By their numbers in this assay, from the lowest: compound 3; then compounds 2 and 1 (each within the scatter of the next).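

In this assay, furan-2-yl in place of phenyl on the aromatic carbon next to the ring nitrogen and next to the ring sulfur gives a step beyond the scatter (a 7.3-fold lower number from compound 1 to compound 3 (0.86 log units; beyond the scatter)), whereas the earlier change of the other aryl group stayed within it (a 1.4-fold lower number from compound 1 to compound 2 (0.16 log units; within the scatter)). This position therefore responds to a ring exchange in a way the earlier pair did not show. The exchange replaces a six-membered aromatic ring of carbon only with a five-membered aromatic ring bearing one oxygen, and nothing here explains the lower number or separates ring size from the oxygen.

From the compounds shown here alone, whether furan-2-yl at this position gives a similar step alongside the 5-methylfuran-2-yl group of compound 2 remains open. Also open, going by these compounds, is how this position responds to a group other than an aromatic ring, such as a morpholine or a primary amine.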